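Hydroxyl Chain in Place of a Branched Alkyl on the Amide

The source may report more compounds than this note shows. Statements on the series, on what has been measured and on what is new or still open speak of the compounds shown alone.

Of the compounds shown here, three sharing a core have been measured in a functional assay on HEK293 cells for positive allosteric modulation of metabotropic glutamate receptor 5 (Rattus norvegicus), read by fluorescence and calcium flux; a higher number here means a larger maximal response, a lower number a smaller maximal response. Compound 1 `Cc1ccc(C#Cc2ccc(C(=O)N[C@H](C)C(C)(C)O)nc2)cc1` gives 63.1% in this assay. Compound 2 `Cc1cc(C#Cc2cccc(F)c2)cnc1C(=O)N[C@H](C)C(C)(C)O` gives 66.4% in this assay. Compound 3 `C[C@@H](NC(=O)c1ccc(C#Cc2cccc(F)c2)cn1)C(C)(C)C` gives 66% in this assay, a number that lies within the usual scatter of both the value of compound 2 and the value of compound 1, so the three cannot be told apart on efficacy.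

Compound 4 `CC(C)(O)CCNC(=O)c1ccc(C#Cc2cccc(F)c2)cn1` has not yet been measured. It differs from compound 3 in one place: 3-hydroxy-3-methylbutyl in place of 1,2,2-trimethylpropyl on an amide-type nitrogen. Among the measured compounds shown here, compounds 1 and 2 both carry a hydroxyl-bearing amide substituent and give maximal responses close to that of compound 3, which carries none, so the three numbers so far give no sign that a hydroxyl group on the amide side chain moves the maximal response.

For the measured compounds named here, on that basis compound 4 is expected to show no step in this assay beyond the scatter, a number 1 percentage points lower from compound 3 to compound 4 (within the scatter). Compound 4 is estimated at 65%, with a range from 50% to 80%.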

Compound 4, largest response reached (reported as efficacy), in percent of the reference or control that the assay uses: 61.9%
For compound 4 the middle estimate is 3.1 percentage points above the measured one; the range from low to high includes it.
By their numbers in this assay, from the lowest: compounds 4, 1, 3 and 2 (each within the scatter of the next).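

Among the compounds shown here, compound 3 and compound 4 form the first pair here that differs in one place, so the effect of a hydroxyl-bearing chain on the amide can now be read directly rather than inferred from compounds that also differ elsewhere. In this assay, putting 3-hydroxy-3-methylbutyl in place of 1,2,2-trimethylpropyl on the amide-type nitrogen gives a number 4.1 percentage points lower from compound 3 to compound 4 (within the scatter), so this position accepts the exchange, which adds a hydrogen-bond donor and acceptor and removes the defined stereocentre, without a step that can be told from the scatter. No measurement shown here bears on what lies behind this result.

For the compounds shown here, the single step also leaves the hydroxyl and the change in the shape of the chain joined together, and a plain 3-methylbutyl chain on the same nitrogen would be needed to separate them. As far as these compounds go, it remains open whether an amine or a carboxylic acid in place of the hydroxyl, or a longer chain, would give a step beyond the scatter in this assay, and the numbers here speak only to the largest response, not to the concentration at which it is reached.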